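This account rests on a few compounds, and the source may have more. Where it says the series, first, only, none or still open, it means among the compounds named here.

Working notes on the series. Compound 1 `COc1cc(/C=C/C(=O)Nc2ccccc2)ccc1OCCCCCN1CCCC1`, compound 2 `COc1cc(/C=C/C(=O)Nc2ccccc2)ccc1OCCCCCCN(C)C` and compound 3 `COc1cc(/C=C/C(=O)Nc2ccccc2)ccc1OCCCCCCN1CCCC1` share one core and differ only in the amine that terminates the chain on an oxygen on an aromatic ring. In a physicochemical assay for lipophilicity, using the shake flask method, measured as octanol-water partition, at pH 7.4 (a lower number here means a more polar compound, a higher number a more lipophilic compound), compound 1 gives 1.64, compound 2 gives 1.69 and compound 3 gives 1.76. The three numbers sit close together: a number 0.05 log units higher from compound 1 to compound 2 (within the scatter), a number 0.12 log units higher from compound 1 to compound 3 (within the scatter) and a number 0.07 log units higher from compound 2 to compound 3 (within the scatter). Compound 3 carries the highest of the three values, but its gaps to compound 2 and to compound 1 both fall within the scatter, so no order among the three can be read from these data.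

The next compound, compound 4 `COc1cc(/C=C/C(=O)Nc2ccccc2)ccc1OCCCCCCCCN(C)C`, is compound 3 with 2-(dimethylamino)ethyl in place of pyrrolidin-1-yl on a saturated chain carbon, six bonds along the chain from an oxygen on an aromatic ring. Two of the measured steps bear on this. The exchange of pyrrolidin-1-yl for dimethylamino at the same chain position is covered by the step from compound 2 to compound 3; lengthening the chain by one carbon is covered by the step from compound 1 to compound 3. Both were small. Compound 4 combines a two-carbon lengthening with the amine swap, so a modest rise in this assay is expected, at the edge of the scatter. For compound 4 the estimate is 1.93, with a range from 1.6 to 2.3, which corresponds to an expected step of a number 0.17 log units higher from compound 3 to compound 4 (within the scatter).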

Compound 4, partition coefficient: 1.74
Compound 4: middle estimate off by 0.19 log units, on the high side, within the range that was stated.
By their numbers in this assay, from the lowest: compounds 1, 2, 4 and 3 (each within the scatter of the next).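

In this assay the exchange of pyrrolidin-1-yl for 2-(dimethylamino)ethyl on a saturated chain carbon, six bonds along the chain from an oxygen on an aromatic ring, gives a small step (a number 0.02 log units lower from compound 3 to compound 4 (within the scatter)), so a group with no ring and a five-membered non-aromatic ring with the same count of heavy atoms cannot be told apart at this position. The longer changes read no differently, with 2-(dimethylamino)ethyl in place of dimethylamino at that same place (a number 0.05 log units higher from compound 2 to compound 4 (within the scatter)) and 3-(dimethylamino)propyl in place of pyrrolidin-1-yl, five bonds along the chain from an oxygen on an aromatic ring (a number 0.10 log units higher from compound 1 to compound 4 (within the scatter)), so the longer chain of compound 4 adds no step beyond the scatter among these four compounds. No supporting data are available to account for the size of these steps.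

The compounds shown leave open whether a still longer chain, or a piperidine or morpholine at the chain end, would give a step beyond the scatter. They also leave open how a carboxylic acid in place of the amine would read in this assay at this position.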